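A few compounds are considered here, and "the series" means these few. Any claim that something is new, unique, unknown or untested is made for them only; others in the source may bear on it.

Series notes. Going by the values given here, the reference is compound 1 `Cc1ccc2[nH]c(=O)c(/C=N/Nc3ccccc3)cc2c1`, which in a functional assay, read by spectrophotometry, with a stated time of 30 min (on this read-out higher numbers stand for weaker inhibition and lower numbers for stronger inhibition), gives 62400 nM, the lowest of the two numbers measured so far. Among the compounds with values here, the comparator compound 2 `N/N=C/c1cc2ccccc2[nH]c1=O` returns in this assay a value of 729000 nM, a higher number lying beyond the scatter; no single-point step links the two, so only the bare values can be set side by side.

Compound 3 `Cc1ccc2[nH]c(=O)c(/C=N/Cc3ccccc3)cc2c1` is still unmeasured. It differs from compound 1 by benzyl in place of anilino on a double-bonded nitrogen. Within the data shown here, with no measured step of this kind on record, a modest rise in the number is expected, beyond the scatter, as a 1.8-fold higher number from compound 1 to compound 3 (0.25 log units; within the scatter). Compound 3 is estimated at 110000 nM, within 35000 nM to 350000 nM.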

Compound 3, half-maximal inhibitory concentration: "not active" (no number reported)
The entry for compound 3 holds no number; the estimate stays without a comparison.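

Going by these compounds alone, compound 3 is entered as "not active" without a number, so no step from compound 1 can be read. The compounds shown leave open how far benzyl in place of anilino moves the value. No evidence on hand bears on this result.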